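A few compounds are considered here, and "the series" means these few. Any claim that something is new, unique, unknown or untested is made for them only; others in the source may bear on it.

Of the compounds shown here, two that share a core have been tested in an assay on NIH3T3 cells for inhibition of Sonic hedgehog protein (Mus musculus), read by a luciferase reporter, with a stated time of 48 h; on this read-out higher numbers stand for weaker inhibition and lower numbers for stronger inhibition. Compound 1 `Cc1cnc(Nc2ccc3[nH]ncc3c2)nc1-c1ccc(OC(F)(F)F)cc1` gives 125 nM in this assay. Compound 2 `Cc1cnc(Nc2ccc(C(=O)Nc3c(C)cccc3C)cc2)nc1-c1ccc(OC(F)(F)F)c(F)c1` gives 159 nM in this assay. These two numbers lie within the scatter of each other, so the measurements do not separate them; compound 2 simply holds the numerically higher of the pair. Among the compounds with values here, no pair of measured compounds differs in a single place, so nothing measured shows how much a change at one position moves this read-out.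

Compound 3 `Cc1cnc(Nc2ccc(C(=O)Nc3c(C)cccc3C)cc2)nc1Cc1ccccc1` is not yet measured. It differs from compound 2 in one place: benzyl in place of 3-fluoro-4-(trifluoromethoxy)phenyl on an aromatic carbon. An aromatic ring attached directly to the core, with its fluorine and oxygen, gives way to a benzyl group, which holds its ring off the core by one carbon and carries no acceptor. Within the data shown here, with no measured step of this kind to lean on, an estimate must rest on the size of the change alone. A step toward weaker inhibition, beyond the scatter, is expected. Compound 3 is thus expected at a step of a 6.3-fold higher number from compound 2 to compound 3 (0.80 log units; beyond the scatter) in this assay. Compound 3 is estimated to give 1000 nM, within a range from 200 nM to 5000 nM.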

Compound 3, half-maximal inhibitory concentration: 34.3 nM
Compound 3: middle estimate off by 29-fold (1.46 log units), on the high side, outside the stated range (below it).
By their numbers in this assay, from the lowest: compound 3; then compounds 1 and 2 (each within the scatter of the next).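

Replacing 3-fluoro-4-(trifluoromethoxy)phenyl with benzyl gives a 4.6-fold lower number from compound 2 to compound 3 (0.67 log units; beyond the scatter) in this assay, the first measured change at a single place among these compounds, and it shows that this position on the six-membered aromatic ring with 2 nitrogen responds to the group placed on it. In this pair, neither the fluorine, nor the trifluoromethoxy group, nor a ring attached directly to the core is needed for inhibition at this level, since benzyl has none of these and gives the lower number. No measurement available here shows why the number falls.

On these data alone, this single step changes several things at once, the added carbon between the ring and the core as well as the loss of the ring's fluorine and trifluoromethoxy group, so the share of each remains unknown. Plain phenyl on the core would test the added carbon alone, while 2-phenylethyl, a longer chain, or 4-methoxybenzyl would show how far the position tolerates more length or a substituted ring.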